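Chloro for bromo: working notes on a small series

The source may report more compounds than this note shows. Statements on the series, on what has been measured and on what is new or still open speak of the compounds shown alone.

Measured so far:
- compound 1, `Cc1ccc(C2=NN(C3=NC(=O)CS3)C(c3ccc4ccccc4c3)C2)cc1`: 12700 nM
- compound 2, `Brc1ccc(C2=NN(C3=NC(c4ccccc4)CS3)C(c3ccc4ccccc4c3)C2)cc1`: 20300 nM
- compound 3, `O=C1CSC(N2N=C(c3ccc(Br)cc3)CC2c2ccc3ccccc3c2)=N1`: 18200 nM

All three numbers come from a functional assay on HepG2 cells (Homo sapiens) for inhibition, read by CCK-8 assay, with a stated time of 48 h; a higher number here means a weaker inhibitor, a lower number a stronger inhibitor. Compound 3 stands second highest of the three numbers, yet its nearest neighbour is compound 2, with a 1.1-fold lower number from compound 2 to compound 3 (0.05 log units; within the scatter), and its furthest is compound 1, with a 1.4-fold higher number from compound 1 to compound 3 (0.16 log units; within the scatter). Both steps are within the scatter, so the three measured compounds cannot be told apart on these data.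

Compound 4, `O=C1CSC(N2N=C(c3ccc(Cl)cc3)CC2c2ccc3ccccc3c2)=N1`, is the next member; it differs from compound 3 in one place: chloro in place of bromo on an aromatic carbon. Going by the values given here, the only measured step that bears on this change is the one at the same aromatic carbon, a 1.4-fold higher number from compound 1 to compound 3 (0.16 log units; within the scatter), which is within the scatter. Among the compounds with values here, no chloro compound has been measured yet. Within the data shown here, with one halogen replacing another at that position and the only comparable step within the scatter, no step beyond the scatter is expected in this assay in either direction, so a 1.0-fold lower number from compound 3 to compound 4 (0.00 log units; within the scatter) is the expected outcome. Compound 4 is therefore estimated at 18000 nM, with a range from 9000 nM to 36000 nM.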

Compound 4, half-maximal inhibitory concentration: 20400 nM
The estimate for compound 4 lay 1.1-fold (0.05 log units) below the measured number; the measured number falls inside the stated range.
By their numbers in this assay, from the lowest: compounds 1, 3, 2 and 4 (each within the scatter of the next).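

Replacing 4-bromophenyl with 4-chlorophenyl on the shared core gives a 1.1-fold higher number from compound 3 to compound 4 (0.05 log units; within the scatter) in this assay, so this halogen exchange at this aromatic carbon now has a direct reading rather than an inference from another substituent. Chloro in place of methyl at the same carbon gives a 1.6-fold higher number from compound 1 to compound 4 (0.21 log units; within the scatter) and also stays within the scatter. Methyl, bromo and chloro at this place therefore cannot be told apart on this core in this assay and no order among them can be drawn.

On these data alone, whether an amine, a carboxylic acid or a longer chain at this carbon would give a step beyond the scatter remains open, as does whether chloro would read the same way on the core of compound 2. No supporting data explain why these three groups read alike.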